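Chloro to bromo on compound 2: working notes

The source may hold more compounds than are shown below. What is called first, only, known or untested is meant among the compounds shown, and "the series" means these compounds.

Two compounds on the shared core form the starting point. For compound 1 `COc1ccc(CNC(=O)c2c(N)sc(C(=O)Nc3ccccc3)c2C)cc1`, the entry in an ADME assay on HepG2 cells (Homo sapiens) for cytotoxicity, read by XTT assay, with a stated time of 2 days (on this read-out lower numbers stand for higher toxicity in this test and higher numbers for lower toxicity in this test), reads "not determined" (no result reported), so it offers no number for comparison. Compound 2 `Cc1cc(NC(=O)c2sc(N)c(C(N)=O)c2C)ccc1Cl` gives > 100000 nM in this assay, and this is a limit of the assay, not a number. The whole quantitative picture is therefore (the limit of > 100000 nM in this assay, at which 1 of the 2 values shown sits), and it belongs to compound 2.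

The next compound is compound 3 `Cc1cc(NC(=O)c2sc(N)c(C(N)=O)c2C)ccc1Br`, with bromo in place of chloro on an aromatic carbon, ortho to a methyl group and para to a large group: bromo in place of chloro on an aromatic carbon. Among the compounds with values here, no step between measured compounds is available to size this exchange. The expectation in this assay is therefore no change beyond the usual scatter, in either direction. That expectation rests on compound 2 alone, whose limit is > 100000 nM. The estimated change is a number no higher from compound 2 to compound 3 (the limit leaves the size open). Another report as a limit is expected. The expected value for compound 3 is 100000 nM, with an estimated range of 40000 nM to 200000 nM.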

Compound 3, half-maximal cytotoxic concentration: 107000 nM
Compound 3: the middle estimate sits 1.1-fold (0.03 log units) below what was measured; the measured number falls inside the stated range.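

Compound 2 gives > 100000 nM in this assay, which is a limit of the assay and not a number. Within the data shown here, compound 3 gives 107000 nM, so no step from compound 2 to compound 3 can be read. The compounds shown leave open the size and direction of any effect of bromo in place of chloro on an aromatic carbon in this assay.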